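A few compounds are considered here, and "the series" means these few. Any claim that something is new, unique, unknown or untested is made for them only; others in the source may bear on it.

Three ureas sharing one core have been measured in a functional assay on HepG2 cells (Homo sapiens) for inhibition, read by MTT assay, with a stated time of 72 h; a higher number here means a weaker inhibitor, a lower number a stronger inhibitor. Compound 1 `Cc1ccc(-n2cc(COc3cccc(NC(=O)Nc4ccc(Cl)c(C(F)(F)F)c4)c3)nn2)cc1` gives 5430 nM in this assay, compound 2 `CC(C)c1cccc(-n2cc(COc3cccc(NC(=O)Nc4ccc(Cl)c(C(F)(F)F)c4)c3)nn2)c1` gives 3250 nM, and compound 3 `O=C(Nc1cccc(OCc2cn(-c3cccc(F)c3)nn2)c1)Nc1ccc(Cl)c(C(F)(F)F)c1` gives 2120 nM. Compound 3 therefore carries the lowest number of the three, though the gap to compound 2 is small: the step of a 1.5-fold lower number from compound 2 to compound 3 (0.19 log units; within the scatter) is within the scatter, whereas the step of a 2.6-fold lower number from compound 1 to compound 3 (0.41 log units; beyond the scatter) is beyond it, so compound 3 can only be called modestly stronger than compound 1.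

Compound 4 `O=C(Nc1cccc(OCc2cn(-c3ccc(Br)cc3)nn2)c1)Nc1ccc(Cl)c(C(F)(F)F)c1` differs from compound 3 in one place: 4-bromophenyl in place of 3-fluorophenyl on an aromatic nitrogen. All three measured steps change the same aryl on the ring nitrogen and bear on this one. The step of a 1.7-fold lower number from compound 1 to compound 2 (0.22 log units; within the scatter) and the step of a 1.5-fold lower number from compound 2 to compound 3 (0.19 log units; within the scatter) were each within the scatter, and the step of a 2.6-fold lower number from compound 1 to compound 3 (0.41 log units; beyond the scatter) only modestly beyond it. Nothing here suggests that swapping one aryl for another at this position moves the number far in either direction. A step of about a 1.4-fold higher number from compound 3 to compound 4 (0.15 log units; within the scatter) is therefore expected, within the scatter of repeated measurement. Compound 4 is estimated to give 3000 nM in this assay, between 1200 nM and 7500 nM.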

Compound 4, half-maximal inhibitory concentration: 2730 nM
Compound 4: middle estimate off by 1.1-fold (0.04 log units), on the high side; the measured number falls inside the stated range.
By their numbers in this assay, from the lowest: compounds 3, 4, 2 and 1 (each within the scatter of the next, the first and the last beyond it).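

In this assay, the step to the 4-bromophenyl group, a 1.3-fold higher number from compound 3 to compound 4 (0.11 log units; within the scatter), changes both the halogen and where it sits on the aryl, yet stays within the scatter, as does a 1.2-fold lower number from compound 2 to compound 4 (0.08 log units; within the scatter). Among the compounds shown here, the direct exchange of bromo for methyl, a 2.0-fold lower number from compound 1 to compound 4 (0.30 log units; within the scatter), is also printed as within the scatter, so among the steps at this position, only the one from compound 1 to compound 3 lies beyond it, and compound 4 cannot be separated from any of the other three compounds. No measurement is available that would explain these small differences.

Because the step from compound 3 to compound 4 alters the halogen and its place together, the compounds shown cannot separate the two; a 3-bromophenyl or 4-fluorophenyl group would be needed for that. From the compounds shown here alone, it also remains open whether an amine or a carboxylic acid on this aryl, or a longer alkyl chain in its place, would move the number further than these aryl groups do, and what a change to the chloro- and trifluoromethyl-bearing aryl of the urea, shared by all four compounds, would do.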